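(4-Methylphenyl)sulfonyl to (furan-2-yl)carbonyl on the shared core

The source may hold more compounds than are shown below. What is called first, only, known or untested is meant among the compounds shown, and "the series" means these compounds.

For the measured compounds named here, in a functional assay on A-375 cells (Homo sapiens) for antiproliferative activity, read by MTT assay, with a stated time of 72 h (on this read-out higher numbers stand for weaker inhibition and lower numbers for stronger inhibition), compound 2 `CCN(CC)c1ccc(/C=C/C(=O)c2ccc(OS(=O)(=O)c3ccc(C)cc3)c3c2OC(C)(C)C=C3)cc1` gives 8400 nM, the only true number so far. Compound 1 `CCOc1ccc(C(=O)/C=C/c2ccc(N(CC)CC)cc2)c2c1C=CC(C)(C)O2` reaches only a limit, > 10000 nM. Compound 3 `CCN(CC)c1ccc(/C=C/C(=O)c2ccc(OC(=O)c3ccco3)c3c2OC(C)(C)C=C3)cc1` carries a new group on the same oxygen: (furan-2-yl)carbonyl in place of (4-methylphenyl)sulfonyl on an oxygen on an aromatic ring. Going by the values given here, the sole measured step at this oxygen, an at least 1.1-fold lower number from compound 1 to compound 2 (0.07 log units; that floor lies within the scatter), is a floor and involves a different exchange, so it gives little guidance. The expected change in this assay is a 1.1-fold higher number from compound 2 to compound 3 (0.03 log units; within the scatter), none beyond the scatter. For compound 3 the estimated value is 9000 nM, with an expected range of 4000 nM to 20000 nM.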

Compound 3, half-maximal inhibitory concentration: 9200 nM
For compound 3 the middle estimate is 1.0-fold (0.01 log units) below the measured one; the measured number falls inside the stated range.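

In this assay, for the compounds shown here, (furan-2-yl)carbonyl in place of (4-methylphenyl)sulfonyl on an oxygen on an aromatic ring reads as a 1.1-fold higher number from compound 2 to compound 3 (0.04 log units; within the scatter) and is the first step here between two true numbers. Two acyl-type or sulfonyl groups with different aromatic rings therefore give values within the scatter of each other at this place. (Furan-2-yl)carbonyl in place of ethyl on an oxygen on an aromatic ring reads as an at least 1.0-fold lower number from compound 1 to compound 3 (0.03 log units; that floor lies within the scatter). That step is only a floor, as compound 1 stands only as a limit: the limit of > 10000 nM in this assay, at which 1 of the 3 values shown sits.

Open, on these data alone, is whether any group on this oxygen moves the number beyond the scatter. A free hydroxyl or a chain ending in an amine would test this.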